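Swapping the hydroxy-acid side chain

The source may report more compounds than this note shows. Statements on the series, on what has been measured and on what is new or still open speak of the compounds shown alone.

Measured compounds:
- compound 1, `O=C(NCc1cc(Cl)ccc1-n1cnnn1)[C@@H]1C[C@@H]2C[C@@H]2N1C(=O)[C@H](O)Cc1ccccn1`: 1000 nM
- compound 2, `O=C(NCc1cc(Cl)ccc1-n1cnnn1)[C@@H]1[C@@H]2C[C@@H]2CN1C(=O)[C@H](O)Cc1ccccn1`: 1700 nM
- compound 3, `CC(C)(C)C[C@@H](O)C(=O)N1NCC[C@H]1C(=O)NCc1cc(Cl)ccc1-n1cnnn1`: 1300 nM

All three were tested in a functional assay on a cell-free system (plasma, Homo sapiens), with a stated time of 3 min; on this read-out lower numbers stand for stronger inhibition and higher numbers for weaker inhibition. Compound 1 gives the lowest of the three numbers, but its gaps to compound 3 and to compound 2 both fall within the usual scatter of repeated measurements, so the three compounds cannot be told apart on these data.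

Compound 4, `CC(C)(C)[C@@H](O)C(=O)N1[C@H](C(=O)NCc2cc(Cl)ccc2-n2cnnn2)C[C@@H]2C[C@@H]21`, has not yet been measured. It keeps the core of compound 1 and differs from it in a single place: tert-butyl in place of (pyridin-2-yl)methyl on a saturated chain carbon bound to a carbonyl carbon and an oxygen on a saturated carbon. Compound 3 carries a tert-butyl group on a longer chain in the same region, and in this assay compound 3 gives 1300 nM, close to compound 1.

For the measured compounds named here, no step between measured compounds isolates this change, so the expectation rests on the closeness of compound 1 and compound 3. The step of a 1.5-fold higher number from compound 1 to compound 4 (0.18 log units; within the scatter) is expected to be small, with a slight lean toward a higher number, most likely not beyond the scatter. In this assay compound 4 is estimated at 1500 nM, within a range of 600 nM to 4000 nM.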

Compound 4, half-maximal inhibitory concentration: 1500 nM
Compound 4: the middle estimate sits on the measured number at the digits printed, and the stated range covers the measured number.
By their numbers in this assay, from the lowest: compounds 1, 3, 4 and 2 (each within the scatter of the next).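

In this assay, putting tert-butyl in place of (pyridin-2-yl)methyl on a saturated chain carbon bound to a carbonyl carbon and an oxygen on a saturated carbon gives a 1.5-fold higher number from compound 1 to compound 4 (0.18 log units; within the scatter). For the compounds shown here, this is the first step in the set that changes one place only, and it shows that this side-chain position can lose a six-membered aromatic ring with 1 hetero atom and 1 hydrogen-bond acceptor, going from 7 heavy atoms to 4, without a shift that rises above the scatter. No measurement at hand accounts for how closely the two groups match in this assay.

As far as these compounds go, the two groups compared here are the only ones at this carbon on this core, so whether an amine or a carboxylic acid in the same place would move the number beyond the scatter remains open. Going by these compounds alone, also open is whether the same swap would give a similarly small step on the core of compound 2, since no pair on that core isolates it.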